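The source may hold more compounds than are shown below. What is called first, only, known or untested is meant among the compounds shown, and "the series" means these compounds.

Two hydrazone-linked thiazoles carrying a nitro group were examined together with their fluoro counterparts. Compound 1 `O=[N+]([O-])c1ccc(-c2csc(N/N=C\c3ccco3)n2)cc1` and compound 2 `O=[N+]([O-])c1ccc(-c2csc(N/N=C\c3c[nH]c4ccccc34)n2)cc1` share the nitro-bearing phenyl on the thiazole, while the difference between the two cores is not broken down here. In an in vitro assay on BTI-TN-5B1-4 cells for inhibition of Amine oxidase [flavin-containing] A (Homo sapiens), read by Amplex Red, with a stated time of 15 min, tested at 100 uM (on this read-out lower numbers stand for less inhibition and higher numbers for more inhibition at the one concentration tested (going by the name of the read-out)), compound 1 gives 40%, whereas compound 2 is reported in this assay as "not active" (no number reported), so no single number stands for it.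

Compound 3 `Fc1ccc(-c2csc(N/N=C\c3ccco3)n2)cc1` is derived from compound 1 by the change (fluoro in place of nitro on an aromatic carbon). In this assay compound 3 gives 40%, and the step of no change at the digits printed from compound 1 to compound 3 (within the scatter) shows that this exchange left the read-out where it was.

Compound 4 `Fc1ccc(-c2csc(N/N=C\c3c[nH]c4ccccc34)n2)cc1`, which has not been measured, relates to compound 2 through the same change, (fluoro in place of nitro on an aromatic carbon), on a place described in the same words as for the pair of compound 1 and compound 3. The step from compound 2 to compound 4 is therefore expected to be small, resting on the step of no change at the digits printed from compound 1 to compound 3 (within the scatter), which showed no change for the nitro-to-fluoro exchange on the other core. Since compound 2 is reported as "not active" (no number reported), the inhibition of compound 4 in this assay is expected to be low. Compound 4 is estimated to give 10% in this assay, with an expected range from 0% to 30%.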

Compound 4, a percentage reported as inhibition, at one concentration (the size of the read-out at that concentration, not a potency): 40%
Compound 4: middle estimate off by 30 percentage points, on the low side; measured number outside the range, above it.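

Going by these compounds alone, compound 2 carries no number in this assay, only the report "not active", while compound 4 gives 40% there, so no step from compound 2 to compound 4 can be read. The compounds shown leave open whether the exchange of nitro for fluoro acts alike on the two cores. No available evidence bears on this result.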